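A few compounds are considered here, and "the series" means these few. Any claim that something is new, unique, unknown or untested is made for them only; others in the source may bear on it.

Three compounds share one core and differ only in the aromatic ring attached to the carbon with a double bond to nitrogen. In a functional assay on SW 1116 cells (Homo sapiens) for cytotoxicity, read by MTT assay, with a stated time of 48 h (on this read-out higher numbers stand for weaker inhibition and lower numbers for stronger inhibition), compound 1 `O=C(CSc1nnc(-c2ccncc2)o1)N/N=C/c1ccc(Cl)cc1` gives 17000 nM. Compound 2 `Cc1ccc(/C=N/NC(=O)CSc2nnc(-c3ccncc3)o2)cc1` gives 16800 nM in this assay. Compound 3 `O=C(CSc1nnc(-c2ccncc2)o1)N/N=C/c1ccccc1[N+](=O)[O-]` gives 30700 nM in this assay, the highest of the three numbers, yet the steps leading to it are small: a 1.8-fold higher number from compound 1 to compound 3 (0.26 log units; within the scatter) and a 1.8-fold higher number from compound 2 to compound 3 (0.26 log units; within the scatter), both within the scatter, as is a 1.0-fold lower number from compound 1 to compound 2 (0.01 log units; within the scatter). Compound 4 `O=C(CSc1nnc(-c2ccncc2)o1)N/N=C/c1cc(Cl)ccc1O` is not yet measured. It differs from compound 3 in one place: 5-chloro-2-hydroxyphenyl in place of 2-nitrophenyl on a carbon with a double bond to nitrogen. The measured steps that bear on this change are the two that swapped one aromatic ring for another at that same carbon, leading from compound 1 and from compound 2 to compound 3; each moved the number by less than the scatter. Nothing among these three compounds shows a ring change at this position moving the number beyond the scatter, so for compound 4 the expected step is a 1.5-fold lower number from compound 3 to compound 4 (0.19 log units; within the scatter), no larger than the scatter. Compound 4 is therefore estimated at 20000 nM in this assay, with a range from 8000 nM to 50000 nM.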

Compound 4, half-maximal inhibitory concentration: 5240 nM
Compound 4: the middle estimate sits 3.8-fold (0.58 log units) above what was measured, outside the stated range (below it).
By their numbers in this assay, from the lowest: compound 4; then compounds 2, 1 and 3 (each within the scatter of the next).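

In this assay, the earlier ring swaps at this carbon stayed within the scatter, but this one does not: the result is a 5.9-fold lower number from compound 3 to compound 4 (0.77 log units; beyond the scatter), and the comparisons with the other two rings agree, with a 3.2-fold lower number from compound 2 to compound 4 (0.51 log units; beyond the scatter) and a 3.2-fold lower number from compound 1 to compound 4 (0.51 log units; beyond the scatter). The ring on the carbon with a double bond to nitrogen can therefore move the number beyond the scatter, and among these four compounds, 5-chloro-2-hydroxyphenyl is the one ring that gives a clearly lower number than each of the others, including the 4-chlorophenyl ring, which also carries a chlorine. Nothing available here explains this drop, and the number itself says nothing about how it comes about.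

The compounds shown leave open whether the hydroxyl, the chlorine or the two together account for the step, as no ring here carries the hydroxyl without the chlorine, or the chlorine in the same place without the hydroxyl. They also leave open whether another group in place of that hydroxyl, such as an amine or a carboxylic acid, would keep the number this low.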